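This account rests on a few compounds, and the source may have more. Where it says the series, first, only, none or still open, it means among the compounds named here.

Measured compounds:
- compound 1 `Cc1nc(N)sc1CCCN/C(N)=N/C(=O)NC(C)c1ccc(Br)cc1`: 55 nM
- compound 2 `CCC(NC(=O)/N=C(\N)NCCCc1sc(N)nc1C)c1ccccc1`: 10.7 nM

In a functional assay on Right cardiac atrium for agonist activity at histamine H2 receptor (Cavia porcellus), with a stated time of 30 min, in the presence of a further agent that is not named here (on this read-out higher numbers stand for an effect only at larger amounts of compound and lower numbers for an effect already at smaller amounts), compound 1 gives the higher of the two numbers, so it needs a larger amount than compound 2, and the gap between them lies beyond the usual scatter of repeated measurements. Compound 3 `Cc1nc(N)sc1CCCN/C(N)=N/C(=O)NC(C)c1cccs1` has not yet been tested in this assay. It differs from compound 1 in one place: thiophen-2-yl in place of 4-bromophenyl on a saturated chain carbon bound to an amide-type nitrogen and a saturated chain carbon. The shared core and the chain carrying the amide-type nitrogen are unchanged. Going by the values given here, there is no step between measured compounds that shows what such an exchange of one aromatic ring for another does in this assay, so the direction is open. The expectation is a step that stays near compound 1, a 1.4-fold lower number from compound 1 to compound 3 (0.14 log units; within the scatter), with no change beyond the scatter the most likely outcome. Compound 3 is therefore estimated at 40 nM, in a range from 12 nM to 130 nM.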

Compound 3, half-maximal effective concentration: 10 nM
The estimate for compound 3 lay 4.0-fold (0.60 log units) above the measured number; measured number below the stated range.
By their numbers in this assay, from the lowest: compounds 3 and 2 (each within the scatter of the next); then compound 1.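

The aromatic ring on the saturated chain carbon bound to an amide-type nitrogen and a saturated chain carbon clearly matters in this assay: putting thiophen-2-yl in place of 4-bromophenyl gives a 5.5-fold lower number from compound 1 to compound 3 (0.74 log units; beyond the scatter) and so moves the effect to smaller amounts of compound. Going by these compounds alone, this is the first one-place step, and it shows that a five-membered aromatic ring with one hetero atom is accepted here and that 4-bromophenyl is not needed for an effect at low amounts. No measurement is available to explain the size or direction of this step.

This single exchange removes the bromine and changes the ring at once, so the compounds shown cannot separate those two parts of the change. From the compounds shown here alone, how 4-chlorophenyl, furan-2-yl or pyridin-2-yl would behave on the same carbon remains open.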